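The compounds below may be only part of what the source reports. "The series", "measured", "known", "first", "only" and "open" are said of these compounds alone.

In a functional assay on PANC-1 cells (Homo sapiens) for inhibition, read by MTT assay, with a stated time of 24 h, tested at 10 uM (on this read-out lower numbers stand for less inhibition and higher numbers for more inhibition at the one concentration tested (going by the name of the read-out)), the measured compounds read:

Compound 1 `CC(C)=CCC/C(C)=C/COc1cc(=O)n(CCCO)c2c1CC(C/C=C(\C)CCC=C(C)C)C(C)(C)C2`: 15.8%
Compound 2 `CC(C)=CCC/C(C)=C/CC1Cc2c(OCCCNC(=O)c3ccco3)cc(=O)n(CCCO)c2CC1(C)C`: 69.5%
Compound 3 `COc1cccc(NC(=O)Oc2cc(=O)n(CCCO)c3c2CC(C/C=C(\C)CCC=C(C)C)C(C)(C)C3)c1`: 47%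

Compound 3 stands second highest of the three in this assay. The two steps that separate it from the others are a number 22.5 percentage points lower from compound 2 to compound 3 (beyond the scatter) and a number 31.2 percentage points higher from compound 1 to compound 3 (beyond the scatter).

Compound 4 `COc1ccccc1NC(=O)Oc1cc(=O)n(CCCO)c2c1CC(C/C=C(\C)CCC=C(C)C)C(C)(C)C2` differs from compound 3 by 2-methoxyphenyl in place of 3-methoxyphenyl on an amide-type nitrogen. Neither measured step bears on this: both exchange the whole group on the oxygen on the aromatic ring, and none moves a methoxy group within a phenyl ring. With no guide of that kind, the expectation in this assay is no step beyond the scatter, no change at the digits printed from compound 3 to compound 4 (within the scatter). Compound 4 is therefore estimated at 47%, with a range from 30% to 64%.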

Compound 4, a percentage reported as inhibition, at one concentration (the size of the read-out at that concentration, not a potency): 53%
Beside the measured number, compound 4's estimate is 6 percentage points below it; the range from low to high includes it.
By their numbers in this assay, from the lowest: compound 1; then compounds 3 and 4 (each within the scatter of the next); then compound 2.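

In this assay, moving the methoxy group, with 2-methoxyphenyl in place of 3-methoxyphenyl on the amide-type nitrogen, gives a number 6 percentage points higher from compound 3 to compound 4 (within the scatter), so this change does not resolve the two phenyl carbamates. The group on the oxygen still separates them from the other compounds, with a number 37.2 percentage points higher from compound 1 to compound 4 (beyond the scatter) and a number 16.5 percentage points lower from compound 2 to compound 4 (beyond the scatter). Nothing at hand explains these steps.

Open, from the compounds shown here alone, is how the read-out responds when a longer alkoxy chain, an amine or a carboxylic acid replaces the methoxy group on the phenyl ring.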